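The compounds below may be only part of what the source reports. "The series", "measured", "known", "first", "only" and "open" are said of these compounds alone.

Compound 2 `Cc1ccc(C2ON=C(c3ccccc3Cl)O2)cc1` in an ADME assay on HEK293 cells (Homo sapiens) for cytotoxicity, read by MTT assay, with a stated time of 44 h (a higher number here means a weaker inhibitor, a lower number a stronger inhibitor), gives > 100000 nM, which is a limit of the assay rather than a number. Compound 1 `Clc1ccc(C2ON=C(c3ccccc3Cl)O2)cc1` in this assay gives > 100000 nM, likewise a limit. Among the measured compounds shown here, the step that the two limits leave unreadable from compound 1 to compound 2 therefore cannot be read for size or direction; the only evidence on hand is the limit of > 100000 nM in this assay, at which 2 of the 2 values shown sit. Compound 3 `CCc1ccc(C2ON=C(c3ccccc3Cl)O2)cc1` carries methyl in place of hydrogen on a saturated chain carbon bound to an aromatic carbon. With no readable step to lean on, the expectation for compound 3 is a step that the limit leaves unreadable from compound 2 to compound 3 that stays within the scatter, and compound 3 is estimated at 150000 nM with a range from 50000 nM to 500000 nM, most likely reported again as a limit.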

Compound 3, half-maximal inhibitory concentration: > 100000 nM
Compound 3: only a limit was reported (the forecaster's own chance of this, stated with the estimate: 85%); the middle value is on the limit's open side.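

No step can be read among compound 1, compound 2 and compound 3 in this assay: the limit of > 100000 nM in this assay, at which 3 of the 3 values shown sit.

Going by these compounds, whether chloro, methyl or ethyl on the shared core makes any difference to the half-maximal inhibitory concentration remains open.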